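The compounds below may be only part of what the source reports. "The series", "measured", "known", "first", "only" and "open" are said of these compounds alone.

In a functional assay on K562 cells (Homo sapiens) for cytotoxicity, read by sulforhodamine B assay (on this read-out lower numbers stand for stronger inhibition of growth and higher numbers for weaker inhibition of growth), compound 1 `COc1ccc(/C=N\NC(=S)NC(C)(C)CCC[C@](C)(O)[C@@H]2CC=C(C)CC2)cc1` gives 220 nM and compound 2 `CC1=CC[C@@H]([C@@](C)(O)CCCC(C)(C)NC(=S)N/N=C\c2ccccc2[N+](=O)[O-])CC1` gives 190 nM. These two numbers are all the series has so far, and they do not separate compound 2 from compound 1. Next is compound 3 `CC1=CC[C@@H]([C@@](C)(O)CCCC(C)(C)NC(=S)N/N=C\c2ccc([N+](=O)[O-])cc2)CC1`, with this change from compound 2: 4-nitrophenyl in place of 2-nitrophenyl on a carbon with a double bond to nitrogen. In words, it carries 4-nitrophenyl in place of 2-nitrophenyl on a carbon with a double bond to nitrogen. Going by the values given here, only one measured step bears on this, a 1.2-fold lower number from compound 1 to compound 2 (0.06 log units; within the scatter), and it exchanged the group at that same place. Among the compounds with values here, no measurement yet compares 2-nitrophenyl with 4-nitrophenyl directly, so that step is only indirect evidence. Resting on compound 2 at 190 nM and on that small step, no change beyond the scatter is expected in this assay. The expected step is a 1.1-fold higher number from compound 2 to compound 3 (0.02 log units; within the scatter). Compound 3 is estimated at 200 nM, with an expected range of 80 nM to 500 nM.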

Compound 3, concentration for 50% growth inhibition: 4220 nM
The estimate for compound 3 lay 21-fold (1.32 log units) below the measured number; the whole stated range lies below it.
By their numbers in this assay, from the lowest: compounds 2 and 1 (each within the scatter of the next); then compound 3.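

In this assay the aryl group on the carbon with a double bond to nitrogen turns out to matter: 4-nitrophenyl in place of 2-nitrophenyl gives a 22-fold higher number from compound 2 to compound 3 (1.35 log units; beyond the scatter) even though the two groups have the same atoms. Nitro in place of methoxy gives a 19-fold higher number from compound 1 to compound 3 (1.28 log units; beyond the scatter) as well. The small earlier step between compound 1 and compound 2 therefore did not mean that this place accepts any group unchanged. Nothing at hand accounts for the weaker growth inhibition of compound 3.

From the compounds shown here alone, compound 1 also carries its group as a 4-substituted phenyl yet stays within the scatter of compound 2, so it remains open whether the loss belongs to 4-nitrophenyl alone. Going by these compounds, whether 4-aminophenyl or 4-chlorophenyl would follow compound 1 or compound 3 also remains open.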